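Chalcone side chain: 3-chlorophenyl to 4-bromophenyl

This account rests on a few compounds, and the source may have more. Where it says the series, first, only, none or still open, it means among the compounds named here.

Compound 1 `O=C(COc1ccc(C(=O)/C=C/c2cccc(Cl)c2)cc1)N[C@H]1CCOC1=O`: 29100 nM
Compound 2 `O=C1OCC[C@@H]1NC(=S)SCCOc1ccccc1`: 53800 nM
Compound 3 `O=C(CNc1ccccc1Cl)N[C@H]1CCOC1=O`: > 64000 nM (a limit of the assay)

Of the compounds shown here, three sharing the lactone amide core have been tested in a functional assay on MGC-803 cells (Homo sapiens) for antiproliferative activity, read by MTT assay, with a stated time of 72 h; on this read-out higher numbers stand for weaker inhibition and lower numbers for stronger inhibition. Compound 1 gives 29100 nM, the lowest of the two actual numbers. Compound 2 gives 53800 nM, and since that lies within the scatter of repeated measurements, the two cannot be ranked against each other. For compound 3 no number was obtained: its result is a limit of the assay, (the limit of > 64000 nM in this assay, at which 1 of the 3 values shown sits). Among the compounds with values here, no two measured compounds differ in only one place, so no measured step is available to guide the next change.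

Compound 4 `O=C(COc1ccc(C(=O)/C=C/c2ccc(Br)cc2)cc1)N[C@H]1CCOC1=O` is built from compound 1 by a change on the chalcone side chain: 4-bromophenyl in place of 3-chlorophenyl on a double-bonded chain carbon bound to a double-bonded chain carbon. With no measured step of this kind shown, the expectation is that the step from compound 1 to compound 4 in this assay stays within the scatter, in no particular direction, at about a 1.1-fold higher number from compound 1 to compound 4 (0.04 log units; within the scatter). Compound 4 is therefore estimated at 32000 nM, with a likely range from 12000 nM to 80000 nM, and with a real chance that the assay again reports only a limit.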

Compound 4, half-maximal inhibitory concentration: 51000 nM
For compound 4 the middle estimate is 1.6-fold (0.20 log units) below the measured one; the range from low to high includes it.
By their numbers in this assay, from the lowest: compounds 1, 4 and 2 (each within the scatter of the next). At a limit, above all of these: compound 3.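

The step gives the series its first direct comparison between two compounds that differ in one place. In this assay, swapping the 3-chlorophenyl group for a 4-bromophenyl group gives a 1.8-fold higher number from compound 1 to compound 4 (0.24 log units; within the scatter), so this exchange produces no difference that can be told apart from the ordinary variation between repeated measurements. Within the data shown here, two features of the group change together here, the halogen and the number in its name, and nothing measured so far offers a reason for the result or separates the share of each.

A 4-chlorophenyl or 3-bromophenyl group at this place would vary one feature at a time, showing whether either matters on its own when the other is held fixed. Going by these compounds, it also remains open whether this position can shift the read-out beyond the scatter at all, for example with a plain phenyl ring or with a ring carrying an amine or a carboxylic acid in place of the halogen.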